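This account rests on a few compounds, and the source may have more. Where it says the series, first, only, none or still open, it means among the compounds named here.

In a functional assay on MCF7 cells (Homo sapiens) for cytotoxicity, read by MTT assay, with a stated time of 72 h (a higher number here means that more compound is tolerated, a lower number that less compound is tolerated), compound 3 `N#C[Se]c1ccc(NC(=O)Oc2ccccc2)cc1` gives 67800 nM. Two close relatives share its core and differ only in the group on the oxygen next to the carbonyl: compound 1 `C=CCOC(=O)Nc1ccc([Se]C#N)cc1` gives 71200 nM, and compound 2 `CCOC(=O)Nc1ccc([Se]C#N)cc1` gives 67800 nM. All three sit at nearly the same level: the step of a 1.1-fold lower number from compound 1 to compound 2 (0.02 log units; within the scatter), the step of a 1.1-fold lower number from compound 1 to compound 3 (0.02 log units; within the scatter) and the step of no change at the digits printed from compound 2 to compound 3 (within the scatter) are each within the scatter, so compound 3 is neither separated from nor ordered against the other two on these numbers.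

Compound 4 `COc1ccc(OC(=O)Nc2ccc([Se]C#N)cc2)cc1` departs from compound 3 by a different kind of change: methoxy in place of hydrogen on an aromatic carbon. None of the three measured steps touches this aromatic ring; they all swap the group on the carbonyl-bound oxygen, and every one of them left the cell-killing concentration essentially unchanged. Among the measured compounds shown here, there is therefore no measured step that speaks directly to this change, and nothing in the data points toward a shift in either direction. The expected outcome is a step of a 1.0-fold lower number from compound 3 to compound 4 (0.02 log units; within the scatter), within the scatter. For compound 4 the estimated value in this assay is 65000 nM, with a range from 35000 nM to 120000 nM.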

Compound 4, concentration lethal to 50% of the cells: 74100 nM
Compound 4: the middle estimate sits 1.1-fold (0.06 log units) below what was measured; measured number inside the range.
By their numbers in this assay, from the lowest: compounds 2, 3, 1 and 4 (each within the scatter of the next).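

Every earlier step exchanged one whole group for another, such as phenyl for ethyl, whereas compound 4 keeps the phenyl and places methoxy on one of its aromatic carbons, para to a large group. In this assay, among the compounds shown here, this gives a 1.1-fold higher number from compound 3 to compound 4 (0.04 log units; within the scatter), so this is the first sign that this aromatic carbon can carry methoxy in place of hydrogen with no shift that stands out from the scatter. Nothing measured here offers an explanation for this result.

From the compounds shown here alone, whether a different kind of group at this place, such as an amine or a carboxylic acid, would shift the number remains open. Going by these compounds, it is also open whether methoxy would give the same result on another carbon of this ring.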